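Swapping thiophen-3-yl for ethynyl in compound 3

This account rests on a few compounds, and the source may have more. Where it says the series, first, only, none or still open, it means among the compounds named here.

Compound 3 `CN(C)c1ncnc2c1c(-c1ccsc1)cn2[C@@H]1O[C@H](CO)[C@@H](O)[C@H]1O` stands at > 100000 nM in an ADME assay on BJ cells (Homo sapiens), read by MTT assay, with a stated time of 72 h (on this read-out lower numbers stand for stronger inhibition and higher numbers for weaker inhibition), and this is a limit of the assay, not a number. Its true value could lie anywhere on that side of the limit, so it makes an uncertain starting point.

Compound 4 `C#Cc1cn([C@@H]2O[C@H](CO)[C@@H](O)[C@H]2O)c2ncnc(N(C)C)c12` has not been measured yet. The change is ethynyl in place of thiophen-3-yl on an aromatic carbon and the rest of the structure stays the same.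

Compound 2 `CN(C)c1ncnc2c1c(-c1ccoc1)cn2[C@@H]1O[C@H](CO)[C@@H](O)[C@H]1O` carries furan-3-yl on that carbon and gives 99200 nM in this assay as a measured number. Among the compounds with values here, the only measured step that touches this group is a number no lower from compound 2 to compound 3 (the limit leaves the size open) and its size stays open, so it sets no scale for the new change.

Compound 1 `C#Cc1cn([C@@H]2O[C@H](CO)[C@@H](O)[C@H]2O)c2ncnc(SC)c12` already carries ethynyl but differs from compound 4 in another place. Compound 1 gives 68600 nM in this assay and this lies within the usual scatter of the value of compound 2.

Resting on compound 1 at 68600 nM as the nearest ethynyl case, a modest move toward stronger inhibition is expected. The expected size is an at least 1.8-fold lower number from compound 3 to compound 4 (0.25 log units; that floor lies within the scatter) as an estimate only.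

Compound 4 is estimated at 55000 nM with an expected range from 12000 nM to 100000 nM in this assay and weak inhibition remains the likely outcome.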

Compound 4, half-maximal inhibitory concentration: 410 nM
For compound 4 the middle estimate is 130-fold (2.13 log units) above the measured one; the whole stated range lies above it.
By their numbers in this assay, from the lowest: compound 4; then compounds 1 and 2 (each within the scatter of the next). At a limit, above all of these: compound 3.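

In this assay, within the data shown here, the compounds with a five-membered aromatic ring on this aromatic carbon showed only weak inhibition, and the swap to ethynyl brings a large change that the earlier compounds gave no hint of: a 240-fold lower number from compound 2 to compound 4 (2.38 log units; beyond the scatter). Against thiophen-3-yl the change reads an at least 240-fold lower number from compound 3 to compound 4 (2.38 log units; beyond the scatter), and this size is only a floor, since compound 3 stands at a limit of the assay and not at a number: the limit of > 100000 nM in this assay, at which 1 of the 4 values shown sits. Ethynyl alone does not account for the low number, as compound 1 carries it too, and dimethylamino in place of methylsulfanyl on the other aromatic carbon gives a 170-fold lower number from compound 1 to compound 4 (2.22 log units; beyond the scatter), so among these compounds only the pairing of ethynyl with dimethylamino reaches this range.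

Going by these compounds, whether the gain comes from the triple bond itself or simply from losing the ring on this carbon stays open, and an ethyl group or a nitrile on the same carbon would help to separate the two. On these data alone, it is also open how much of the dimethylamino group is needed, which a plain amine or a methylamino group at that place could test.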